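The source may hold more compounds than are shown below. What is called first, only, known or untested is meant among the compounds shown, and "the series" means these compounds.

Measured compounds in a functional assay on HT-29 cells (Homo sapiens) for antiproliferative activity; a lower number here means a stronger inhibitor, a higher number a weaker inhibitor:

compound 1, `CC1(C)CNC(=O)c2sc(Nc3ccc(I)cc3F)c(C(=O)NCCCO)c2C1`: 6210 nM
compound 2, `CC1(C)CNC(=O)c2sc(Nc3ccc(I)cc3F)nc2C1`: 8870 nM
compound 3, `CC(C)(N)CNC(=O)c1c(Nc2ccc(I)cc2Cl)sc2c1CC(C)(C)CNC2=O`: 113 nM

Compound 1 stands second highest of the three numbers in this assay. Its nearest neighbour is compound 2, whose value lies within the scatter of that of compound 1, so nothing can be said about an order between the two. Compound 3 sits far lower, well beyond the scatter, and is the only one of the three with a strong number.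

The next compound, compound 4, `CC1(C)CNC(=O)c2sc(Nc3ccc(I)cc3F)c(C(N)=O)c2C1`, keeps the core of compound 1 with one change at the amide:

hydrogen in place of 3-hydroxypropyl on an amide-type nitrogen

Among the measured compounds shown here, no measured pair shows this change, so its effect is not known from the data. Compound 3 shows that the amide substituent can matter a great deal, but compound 3 differs from compound 1 in more than one place, and the hydroxypropyl itself has not been varied against hydrogen in any measured pair. In this assay the step from compound 1 to compound 4 is expected to be small, a 1.2-fold lower number from compound 1 to compound 4 (0.09 log units; within the scatter), with no clear direction beyond the scatter. Compound 4 is estimated at 5000 nM, in the range 1500 nM to 16000 nM.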

Compound 4, half-maximal inhibitory concentration: 158 nM
Estimate against measurement, compound 4: 32-fold (1.50 log units) above; measured number below the stated range.
By their numbers in this assay, from the lowest: compounds 3 and 4 (each within the scatter of the next); then compounds 1 and 2 (each within the scatter of the next).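

In this assay the change from 3-hydroxypropyl to hydrogen on the amide-type nitrogen gives a 39-fold lower number from compound 1 to compound 4 (1.59 log units; beyond the scatter) and is a large step. Among the compounds shown here, it is the first pair to vary this position alone, and it shows that the substituent there can decide between a weak and a strong number on the core of compound 1. No evidence on hand accounts for the size of this step.

Going by these compounds, with only hydrogen and 3-hydroxypropyl compared directly, it stays open whether the chain or its terminal hydroxyl carries the loss, and a plain propyl would separate the two. Also open, on these data alone, is how a methyl, a longer chain or a carboxylic acid on this nitrogen would fall relative to compound 1 and compound 4.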